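Mirror-image partner of compound 2 awaits its cytotoxicity number

The source may hold more compounds than are shown below. What is called first, only, known or untested is meant among the compounds shown, and "the series" means these compounds.

Measured in a functional assay on HCT-116 cells (Homo sapiens) for cytotoxicity (a lower number here means a stronger inhibitor, a higher number a weaker inhibitor), so far:
Compound 1 `COc1ccc(C2=C(c3ccccc3)C(=O)N3CCCC3C2)cc1` gives 390 nM
Compound 2 `COc1ccc(C2=C(c3ccccc3)C(=O)N3CCC[C@@H]3C2)cc1` gives 200 nM

Compound 2 stands within the scatter of compound 1, as shown by a 2.0-fold lower number from compound 1 to compound 2 (0.29 log units; within the scatter) and nothing firmer. Compound 3 `COc1ccc(C2=C(c3ccccc3)C(=O)N3CCC[C@H]3C2)cc1` differs from compound 2 as follows: the two compounds have the same atoms and bonds and differ only in configuration as drawn: 1 of 1 stereo elements differ; a stereocentre at a saturated ring carbon is drawn R in compound 2 and S in compound 3 and in nothing else. For the measured compounds named here, only that one measured step bears on this stereocentre. If compound 1 is a mixture of both forms, a 2.0-fold lower number from compound 1 to compound 2 (0.29 log units; within the scatter) hints, weakly, that the S form contributes little. A clear move towards a higher number in this assay is therefore expected, with wide uncertainty. The expected change is a 7.5-fold higher number from compound 2 to compound 3 (0.88 log units; beyond the scatter) in this estimate. For compound 3 the estimated value is 1500 nM within an expected range of 300 nM to 10000 nM overall.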

Compound 3, half-maximal inhibitory concentration: 390 nM
Compound 3: the middle estimate sits 3.8-fold (0.59 log units) above what was measured, and the stated range covers the measured number.
By their numbers in this assay, from the lowest: compounds 2, 1 and 3 (each within the scatter of the next).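

In this assay, inverting the stereocentre at the saturated ring carbon from R to S gives a 2.0-fold higher number from compound 2 to compound 3 (0.29 log units; within the scatter), so the two drawn forms are not told apart at this position. The form drawn without a configuration does not separate from the S form either, with no change at the digits printed from compound 1 to compound 3 (within the scatter). The earlier hint that the S form contributes little therefore finds no support, and this assay shows no clear preference for either configuration here.

On these data alone, it stays open whether either form would separate from the other in a different assay. Also open, as far as these compounds go, is whether a hydroxyl or an amine at this stereocentre would move the number in this assay beyond the scatter.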